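The source may hold more compounds than are shown below. What is called first, only, known or untested is meant among the compounds shown, and "the series" means these compounds.

Of the compounds shown here, three built on one shared core have been measured in a functional assay on UACC-62 cells (Homo sapiens) for antiproliferative activity, read by sulforhodamine B assay, with a stated time of 48 h; on this read-out lower numbers stand for stronger inhibition and higher numbers for weaker inhibition. Compound 1 `COc1cc(-c2nn(-c3ccc(NC(=O)Nc4ccc(Cl)c(Cl)c4)cc3)cc2-c2ccncc2)ccc1Cl` gives 3350 nM, compound 2 `COc1cc(-c2nn(-c3ccc(NC(=O)c4ccc(Cl)c(Cl)c4)cc3)cc2-c2ccncc2)ccc1Cl` gives 6340 nM, and compound 3 `COc1cc(-c2nn(-c3ccc(NC(=O)c4cc(Cl)cc(Cl)c4)cc3)cc2-c2ccncc2)ccc1Cl` gives 4580 nM. Compound 3 stands second highest of these three numbers; its nearest neighbour is compound 1 and its furthest is compound 2, and both gaps lie within the scatter. The untested compound 4 `COc1cc(-c2nn(-c3ccc(NC(=O)c4ccc(Cl)c(C(F)(F)F)c4)cc3)cc2-c2ccncc2)ccc1Cl` differs from compound 3 in one place: 4-chloro-3-(trifluoromethyl)phenyl in place of 3,5-dichlorophenyl on a carbonyl carbon. Every step measured so far alters the group attached to that same carbonyl carbon: a 1.9-fold higher number from compound 1 to compound 2 (0.28 log units; within the scatter), a 1.4-fold higher number from compound 1 to compound 3 (0.14 log units; within the scatter) and a 1.4-fold lower number from compound 2 to compound 3 (0.14 log units; within the scatter). Each stayed within the scatter, so exchanging the aromatic group on this carbonyl carbon has so far left this assay essentially unmoved. For compound 4 the expected step is therefore a 1.0-fold lower number from compound 3 to compound 4 (0.01 log units; within the scatter), which amounts to none beyond the scatter. Compound 4 is accordingly estimated at 4500 nM, with a plausible range from 2000 nM to 10000 nM.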

Compound 4, half-maximal inhibitory concentration: 2180 nM
For compound 4 the middle estimate is 2.1-fold (0.31 log units) above the measured one, and the stated range covers the measured number.
By their numbers in this assay, from the lowest: compounds 4, 1, 3 and 2 (each within the scatter of the next, the first and the last beyond it).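

In this assay, the group on this carbonyl carbon can now be seen to matter: 4-chloro-3-(trifluoromethyl)phenyl gives a step beyond the scatter against 3,5-dichlorophenyl, a 2.1-fold lower number from compound 3 to compound 4 (0.32 log units; beyond the scatter), and so does trifluoromethyl in place of chloro on an aromatic carbon, a 2.9-fold lower number from compound 2 to compound 4 (0.46 log units; beyond the scatter). The shift remains modest, and the new group cannot be told apart from (3,4-dichlorophenyl)amino on the same carbonyl carbon, a 1.5-fold lower number from compound 1 to compound 4 (0.19 log units; within the scatter). Nothing available explains the difference between these groups.

The compounds shown leave open whether trifluoromethyl itself carries this shift, which a nitrile or a methyl group in its place could help to test. They also leave open whether 4-chloro-3-(trifluoromethyl)phenyl would behave the same way if attached through an amino group, as the dichlorophenyl ring of compound 1 is.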